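A few compounds are considered here, and "the series" means these few. Any claim that something is new, unique, unknown or untested is made for them only; others in the source may bear on it.

Of the compounds shown here, two have been tested so far in a functional assay on HepG2 cells (Homo sapiens) for inhibition, read by MTT assay, with a stated time of 72 h; on this read-out lower numbers stand for stronger inhibition and higher numbers for weaker inhibition. Compound 1, with the structure `O=c1cc(Cn2cc(CSC(=S)N3CCNCC3)nn2)c2ccc(O)cc2o1`, returns only a limit of the assay, > 100000 nM, and no number. Compound 2, with the structure `Cc1ccc2nc(-c3ccc(NCc4cn(Cc5cc(=O)oc6cc(O)ccc56)nn4)cc3)sc2c1`, gives 52800 nM in this assay, which is the only actual number shown; the other value sits at the limit of > 100000 nM in this assay, at which 1 of the 2 values shown sits. Compound 3, with the structure `Cc1ccc2c(Cn3cc(CNc4ccc(-c5nc6ccc(C)cc6s5)cc4)nn3)cc(=O)oc2c1`, has not yet been measured in this assay. It differs from compound 2 in one place: methyl in place of hydroxy on an aromatic carbon. For the measured compounds named here, with no measured pair of this kind to compare against, the size of the step is open, and the expectation is a change no larger than the usual scatter from compound 2 to compound 3 in this assay, namely a 1.1-fold higher number from compound 2 to compound 3 (0.06 log units; within the scatter). The estimate for compound 3 in this assay is 60000 nM, with a range from 20000 nM to 180000 nM.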

Compound 3, half-maximal inhibitory concentration: 94700 nM
Compound 3: middle estimate off by 1.6-fold (0.20 log units), on the low side; measured number inside the range.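

In this assay, the exchange of hydroxy for methyl on this aromatic carbon gives a 1.8-fold higher number from compound 2 to compound 3 (0.25 log units; within the scatter). For the compounds shown here, this is the first measured pair at this position, and it shows that a hydroxy with its hydrogen-bond donor and acceptor can give way to a methyl with neither without the number leaving the usual scatter. The pair therefore gives no sign that the hydroxy is needed for the weak inhibition seen here, though compound 1 reports only a limit and not a number: the limit of > 100000 nM in this assay, at which 1 of the 3 values shown sits.

The compounds shown leave open how an amine, a methoxy group or a carboxylic acid on this aromatic carbon would read. One pair with weak values also cannot tell whether this position would matter the same way in a compound with much stronger inhibition.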